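A few compounds are considered here, and "the series" means these few. Any claim that something is new, unique, unknown or untested is made for them only; others in the source may bear on it.

Measured compounds:
Compound 1, `CCCn1c(=O)[nH]c2nc(-c3ccc(S(=O)(=O)N4CCN(c5ccccc5Br)CC4)cc3)[nH]c2c1=O` — in an assay on CHO cells for displacement of a labelled ligand from adenosine receptor A3 (Homo sapiens), read by scintillation counting, with a stated time of 45 min, in the presence of a further agent that is not named here (a higher number here means a weaker inhibitor, a lower number a stronger inhibitor), compound 1 gives > 1000 nM, which is a limit of the assay and not a number.
Compound 2, `CCCn1c(=O)[nH]c2nc(-c3ccc(S(=O)(=O)N4CCN(c5ccc(I)cc5)CC4)cc3)[nH]c2c1=O` — in this assay compound 2 gives > 1000 nM, again a limit and not a number.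

Going by the values given here, compound 2 therefore stands only at a limit, and the one other value shown for this series is a limit as well. The step that the two limits leave unreadable from compound 1 to compound 2 cannot be read, since both ends sit at the same limit; what is known is the limit of > 1000 nM in this assay, at which 2 of the 2 values shown sit.

Compound 3, `CCCn1c(=O)[nH]c2nc(-c3ccc(S(=O)(=O)N4CCN(c5ccccc5Cl)CC4)cc3)[nH]c2c1=O`, has not yet been measured in this assay. It differs from compound 2 by 2-chlorophenyl in place of 4-iodophenyl on an amine nitrogen in a ring. Among the compounds with values here, the only measured step that bears on this change is the unreadable one, so no size or direction can be taken from it; the change returns to a phenyl substituted at the same position as in compound 1, which also sits at the limit.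

Compound 3 is therefore expected to stay at or near that limit, with an estimated 3000 nM (range 1000 nM to 10000 nM), and the step that the limit leaves unreadable from compound 2 to compound 3 is expected to be no more than scatter.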

Compound 3, inhibition constant: > 1000 nM
Compound 3: no number, only a limit; the forecaster's own chance of this, stated with the estimate: 85%; the middle value does not contradict the limit.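

Compound 3, like compound 1 and compound 2, gives only a limit and not a number in this assay, so no step among these three compounds can be read: the limit of > 1000 nM in this assay, at which 3 of the 3 values shown sit.

The compounds shown leave open how strong each of the three actually is, and whether any other group on that amine nitrogen in a ring would give a readable value.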